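The compounds below may be only part of what the source reports. "The series", "measured", "known", "first", "only" and "open" are said of these compounds alone.

Compound 1 `COc1ccc(C(=O)Nc2cc(-c3ccccc3)nn2-c2ccccc2)cc1` gives 420 nM in an assay on HEK293 cells for displacement of a labelled ligand from metabotropic glutamate receptor 5 (Rattus norvegicus); on this read-out lower numbers stand for stronger inhibition and higher numbers for weaker inhibition.
Compound 2 `O=C(Nc1cc(-c2ccccc2)nn1-c1ccccc1)c1ccc([N+](=O)[O-])cc1` gives 250 nM in this assay.

Of the two measured compounds, compound 2 carries the lower number, but the step of a 1.7-fold lower number from compound 1 to compound 2 (0.23 log units; within the scatter) lies within the usual scatter, so the two values cannot be told apart with confidence, and neither compound can be called the stronger of the pair. Compound 3 `O=C(Nc1cc(-c2ccccc2)nn1-c1ccccc1)c1ccc(Cl)c(Cl)c1` is not yet measured in this assay. It differs from compound 2 in one place: 3,4-dichlorophenyl in place of 4-nitrophenyl on a carbonyl carbon. Among the measured compounds shown here, the only measured step that bears on this change is the one from compound 1 to compound 2, which also exchanged the group on the ring attached to the carbonyl carbon, and that step stayed within the scatter. On that basis, the exchange in compound 3 is expected to leave the number in this assay where compound 2 stands, with no step beyond the scatter: the estimated step is a 1.2-fold higher number from compound 2 to compound 3 (0.08 log units; within the scatter). Compound 3 is therefore expected to give about 300 nM in this assay, within a range from 100 nM to 900 nM.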

Compound 3, inhibition constant: 160 nM
Beside the measured number, compound 3's estimate is 1.9-fold (0.27 log units) above it; the range from low to high includes it.
By their numbers in this assay, from the lowest: compounds 3, 2 and 1 (each within the scatter of the next, the first and the last beyond it).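

Among the groups on the carbonyl carbon, 3,4-dichlorophenyl provides the first comparison in this assay that clears the usual scatter: exchanging 4-methoxyphenyl for it gives a modest change (a 2.6-fold lower number from compound 1 to compound 3 (0.42 log units; beyond the scatter)). Exchanging 4-nitrophenyl for the same group gives no change that can be distinguished (a 1.6-fold lower number from compound 2 to compound 3 (0.19 log units; within the scatter)), so compound 2 cannot be separated from either compound 1 or compound 3, and only the two ends of this short series stand apart. The position therefore responds to a change of aryl group, but only modestly across these three compounds, and no supporting measurement is available to say what lies behind the difference between the 4-methoxyphenyl and 3,4-dichlorophenyl groups.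

The compounds shown leave open whether the two chlorines are both needed, since a single chlorine on this ring does not appear among them, and how a ring carrying an amine or a carboxylic acid would read in this assay. They also leave open whether a longer chain in place of the aryl group on the carbonyl carbon would keep a number in this range.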